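From Cyclohexyloxy to Cyclopentyloxy

The compounds below may be only part of what the source reports. "The series", "measured", "known", "first", "only" and "open" are said of these compounds alone.

Of the compounds shown here, two have been measured so far, compound 1 `C[C@@H](Oc1cc(C(=O)N(C)C)ccc1Nc1nc(O[C@H]2CC[C@@](C)(O)CC2)c2cc[nH]c2n1)C(F)(F)F` and compound 2 `COc1cc(C(=O)N(C)C)ccc1Nc1nc(OC2CCCCC2)c2cc[nH]c2n1`. In a functional assay on CAL-51 cells (Homo sapiens) for antiproliferative activity, read by luminescence and CellTiter-Glo, with a stated time of 3 days (a higher number here means a weaker inhibitor, a lower number a stronger inhibitor), compound 1 gives 24 nM and compound 2 gives 190 nM. Compound 2 therefore holds the higher of the two numbers, making it the weaker inhibitor, with a gap beyond the scatter. Compound 3 `COc1cc(C(=O)N(C)C)ccc1Nc1nc(OC2CCCC2)c2cc[nH]c2n1` carries cyclopentyl in place of cyclohexyl on an oxygen on an aromatic ring. Among the compounds with values here, the measured compounds include no pair that differs in one place, so the data offer no direct guide to the size of this change. A small shift towards a higher number in this assay is expected, possibly no larger than the scatter. The estimated step is a 1.3-fold higher number from compound 2 to compound 3 (0.12 log units; within the scatter). For compound 3 the expected value is 250 nM, with an estimated range of 90 nM to 700 nM.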

Compound 3, half-maximal inhibitory concentration: 497 nM
For compound 3 the middle estimate is 2.0-fold (0.30 log units) below the measured one; the measured number falls inside the stated range.
By their numbers in this assay, from the lowest: compound 1; then compound 2; then compound 3.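

In this assay, within the data shown here, cyclopentyl in place of cyclohexyl on an oxygen on an aromatic ring gives a 2.6-fold higher number from compound 2 to compound 3 (0.42 log units; beyond the scatter) and supplies the first one-place comparison. The size of the carbon ring at this position therefore matters to the read-out: going from 6 heavy atoms to 5 moves the number beyond the scatter, and of these two rings cyclohexyl gives the lower number. No measurement at hand offers a reason for this step.

Compound 1 differs from compound 2 in more than one place. No single one of those differences can be read from their numbers. Also open, as far as these compounds go, is whether the trend continues to a larger carbon ring such as cycloheptyl, and how an open-chain isopropyl group or a ring bearing an amine behaves on the same oxygen.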